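Moving from Compound 3 to Compound 4 at the Purinoceptor

The source may hold more compounds than are shown below. What is called first, only, known or untested is meant among the compounds shown, and "the series" means these compounds.

Of the compounds shown here, three have been tested in an assay on RPMI-8226 cells for antagonist activity at P2X purinoceptor 7 (Homo sapiens), read by calcium flux; on this read-out lower numbers stand for stronger inhibition and higher numbers for weaker inhibition. Compound 1 `Cc1ccc(S(=O)(=O)N2CCN(CCCn3c(=O)[nH]c4ccccc43)CC2)cc1` gives only a limit there, > 10000 nM, a boundary rather than a number (the limit of > 10000 nM in this assay, at which 1 of the 3 values shown sits). Compound 2 `O=c1[nH]c2ccccc2n1CCCN1CCC(=C(c2ccccc2)c2ccccc2)CC1` gives 2400 nM. Compound 3 `Cc1nc2ccccc2n1CCCCN1CCN(C(c2ccccc2)c2ccccc2)CC1` gives 850 nM, the lowest of the two numbers shown; compound 2 sits at a higher number, and that gap lies beyond the usual scatter of repeated measurements. Compound 4 `Fc1cccc2c1ccn2CCCCN1CCN(C(c2ccccc2)c2ccccc2)CC1` has not yet been measured. It differs from compound 3 in one place: 4-fluoro-1H-indol-1-yl in place of 2-methyl-1H-benzimidazol-1-yl on a saturated chain carbon, four bonds along the chain from an amine nitrogen in a ring. Among the measured compounds shown here, no measured pair of compounds shows this change, so nothing among the measured values tells how large its effect is or which way it points. A step of modest size in either direction, or none beyond the scatter, is equally plausible. Compound 4 is therefore expected to stay close to the number of its parent, the estimated step being a 1.2-fold lower number from compound 3 to compound 4 (0.08 log units; within the scatter). For compound 4 the estimated value in this assay is 700 nM, with a range from 200 nM to 2500 nM.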

Compound 4, half-maximal inhibitory concentration: 150 nM
For compound 4 the middle estimate is 4.7-fold (0.67 log units) above the measured one; the whole stated range lies above it.
By their numbers in this assay, from the lowest: compound 4; then compound 3; then compound 2. At a limit, above all of these: compound 1.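

In this assay, 4-fluoro-1H-indol-1-yl in place of 2-methyl-1H-benzimidazol-1-yl gives a 5.7-fold lower number from compound 3 to compound 4 (0.75 log units; beyond the scatter), so the group on this saturated chain carbon, four bonds along the chain from an amine nitrogen in a ring, clearly affects the result. Among the compounds shown here, this is the first step between compounds that differ in one place, and it gives this change both a size and a direction. The swap alters several things at once, since a ring nitrogen and the methyl leave and a fluorine enters, and nothing measured here accounts for the step.

Which of these alterations matters remains open. Plain 1H-indol-1-yl without the fluorine, or the same indole with a chlorine in place of the fluorine, would help to separate the contribution of the ring from that of the halogen.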